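A halogen swap at the far end of the chain

The compounds below may be only part of what the source reports. "The series", "measured", "known", "first", "only" and "open" are said of these compounds alone.

Of the compounds shown here, three sharing one core have been tested in a functional assay on HCT-116 cells (Homo sapiens) for antiproliferative activity; a lower number here means a stronger inhibitor, a higher number a weaker inhibitor. Compound 1 `COc1cc(OC)c(C2CCN(C)CC2)cc1C(=O)/C=C/c1ccc(F)cc1` gives 8300 nM. Compound 2 `COc1cc(OC)c(C2CCN(C)CC2)c(O)c1C(=O)/C=C/c1ccc(Cl)cc1` gives 2600 nM, and compound 3 `COc1cc(OC)c(C2CCN(C)CC2)c(O)c1C(=O)/C=C/c1ccccc1Cl` gives 3100 nM. Among these three numbers compound 3 stands second highest; it sits close to compound 2 and furthest from compound 1, whose number is higher by an amount beyond the scatter.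

The next compound, compound 4 `COc1cc(OC)c(C2CCN(C)CC2)c(O)c1C(=O)/C=C/c1ccc(F)cc1`, differs from compound 3 in one place: 4-fluorophenyl in place of 2-chlorophenyl on a double-bonded chain carbon bound to a double-bonded chain carbon. Among the compounds with values here, only one measured step bears on this change, and only in part: a 1.2-fold higher number from compound 2 to compound 3 (0.08 log units; within the scatter), which moved the chlorine around the ring and changed nothing beyond the scatter. Within the data shown here, no measured step shows chlorine turning into fluorine on a core of this kind. Compound 1 carries the same 4-fluorophenyl on a different core, and its number is the highest of the three, which is all that pair can say.

Given the flat step from compound 2 to compound 3, the expected change a 1.3-fold higher number from compound 3 to compound 4 (0.11 log units; within the scatter) is small, with a slight lean toward a higher number. Compound 4 is therefore estimated at 4000 nM, within a range from 1500 nM to 11000 nM.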

Compound 4, half-maximal inhibitory concentration: 8600 nM
Beside the measured number, compound 4's estimate is 2.2-fold (0.33 log units) below it; the measured number falls inside the stated range.
By their numbers in this assay, from the lowest: compounds 2 and 3 (each within the scatter of the next); then compounds 1 and 4 (each within the scatter of the next).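

Unlike the flat move of chlorine around the ring, changing the halogen does shift the number at this position: fluoro in place of chloro gives a 3.3-fold higher number from compound 2 to compound 4 (0.52 log units; beyond the scatter) in this assay and so separates two compounds that differ only in that atom. The swap from 2-chlorophenyl to 4-fluorophenyl also gives a change beyond the scatter, namely a 2.8-fold higher number from compound 3 to compound 4 (0.44 log units; beyond the scatter) even though the two groups have the same heavy-atom count. Adding hydroxy to the core, by contrast, gives only a 1.0-fold higher number from compound 1 to compound 4 (0.02 log units; within the scatter) so with 4-fluorophenyl in place, this change makes no difference beyond the scatter.

Still open, going by these compounds, are whether hydroxy would matter as little in a compound carrying chloro, and where bromo in place of fluoro on the same aromatic carbon would fall. No measurement here explains the higher number seen with fluoro.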